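The source may hold more compounds than are shown below. What is called first, only, known or untested is meant among the compounds shown, and "the series" means these compounds.

Measured compounds:
- compound 1 `Cc1oc2ncnc(Nc3cccc(Br)c3)c2c1C(=O)O`; in a functional assay on A549 cells (Homo sapiens) for cytotoxicity, read by MTT assay, with a stated time of 72 h (on this read-out higher numbers stand for weaker inhibition and lower numbers for stronger inhibition), compound 1 gives 43000 nM.
- compound 2 `CCOC(=O)c1c(C)oc2ncnc(Nc3cccc(Br)c3)c12`; in this assay compound 2 gives only a limit, > 1000000 nM.

Compound 1 therefore stands as the single numeric result in this assay, the other result being a limit. For the measured compounds named here, the one measured step, an at least 23-fold higher number from compound 1 to compound 2 (1.36 log units; beyond the scatter), concerns the ester in place of the free acid, and it ends at a limit (the limit of > 1000000 nM in this assay, at which 1 of the 2 values shown sits).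

Compound 3 `Cc1cccc(Nc2ncnc3oc(C)c(C(=O)O)c23)c1` differs from compound 1 by methyl in place of bromo on an aromatic carbon. Going by the values given here, this change sits on the aryl ring, away from the carboxyl position that the measured step of an at least 23-fold higher number from compound 1 to compound 2 (1.36 log units; beyond the scatter) addresses, so no measured step bears directly on it. With nothing in the data pointing in either direction, a step no larger than the usual scatter is expected, and the estimated step is a 1.4-fold higher number from compound 1 to compound 3 (0.14 log units; within the scatter). Compound 3 is thus expected to give about 60000 nM in this assay, with a range from 15000 nM to 250000 nM, with some chance that only a limit is reported.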

Compound 3, half-maximal inhibitory concentration: 100000 nM
Compound 3: middle estimate off by 1.7-fold (0.22 log units), on the low side; the measured number falls inside the stated range.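

In this assay, for the compounds shown here, no earlier step touched the aryl ring, and a 2.3-fold higher number from compound 1 to compound 3 (0.37 log units; beyond the scatter) is the first reading there: the change from 3-bromophenyl to 3-methylphenyl is one this assay can detect, and bromo is the member of the pair with the lower number. The change is modest, and it moves the number less than the ester in place of the free acid does, an at least 23-fold higher number from compound 1 to compound 2 (1.36 log units; beyond the scatter), so this aryl position tolerates the swap with a measurable but limited shift while the compound remains on the numeric part of the scale. Nothing shown gives a measured property that would account for the difference between bromo and methyl.

Open, as far as these compounds go, is how other groups at this same place would read, such as chloro, methoxy or an amine, and whether the difference between bromo and methyl would persist with an amide or a longer chain in place of the carboxylic acid. With only bromo and methyl compared here, the two values give a single step and no trend across the aryl ring.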